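The source may report more compounds than this note shows. Statements on the series, on what has been measured and on what is new or still open speak of the compounds shown alone.

In a functional assay on MCF7 cells (Homo sapiens) for inhibition (on this read-out higher numbers stand for weaker inhibition and lower numbers for stronger inhibition), compound 1 `CCc1cc(N)ccc1-c1nc2ccccc2s1` gives < 0.1 nM, which is a limit of the assay and not a number. Compound 2 `Cc1ccc2nc(-c3ccc(N)cc3I)sc2c1` gives < 0.1 nM, which is also a limit. Compound 3 `Nc1ccc(-c2nc3ccccc3s2)cc1Cl` gives < 0.1 nM, again a limit. The three compounds thus share one result, (the limit of < 0.1 nM in this assay, at which 3 of the 3 values shown sit), and these results cannot put them in any order.

Compound 4 `Nc1ccc(-c2nc3ccccc3s2)c(Cl)c1` keeps the core of compound 1 and changes one group: chloro in place of ethyl on an aromatic carbon. In words, this is chloro in place of ethyl on an aromatic carbon, ortho to a group of 9 heavy atoms and meta to an amino group. Among the compounds with values here, no two measured compounds differ in just one place, so no measured step shows how large this change might be.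

The expectation in this assay is therefore no step beyond the usual scatter, and it is only a cautious one. It rests on compound 1 with its limit of < 0.1 nM. The expected size of the change is a number no lower from compound 1 to compound 4 (the limit leaves the size open). For compound 4 the estimated value is 0.1 nM, within an expected range of 0.03 nM to 1 nM.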

Compound 4, half-maximal inhibitory concentration: < 0.1 nM
Compound 4 ended at the assay's limit; the forecaster's own chance of this, stated with the estimate: 65%; the middle value lies on the limit itself.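

In this assay compound 1 and compound 4 both end at a limit and not at a number, so no step can be read between them. The evidence for this is plain: the limit of < 0.1 nM in this assay, at which 4 of the 4 values shown sit. The compounds shown leave open how strong each one really is, and whether chloro in place of ethyl on an aromatic carbon changes inhibition at all.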